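Thiophen-2-yl in place of 2,6-dimethylphenyl: working notes

The source may report more compounds than this note shows. Statements on the series, on what has been measured and on what is new or still open speak of the compounds shown alone.

In a functional assay on KB cells (Homo sapiens) for cytotoxicity (a lower number here means that less compound is needed, a higher number that more compound is needed for the effect), compound 1 `COC1=C(C)C(=O)/C(=C(O)/C=C/c2ccc(O)cc2)C(=O)C1(C)C` gives 3 ug/mL and compound 2 `COC1=C(C)C(=O)/C(=C(O)/C=C/c2c(C)cccc2C)C(=O)C1(C)C` gives 2.1 ug/mL. These two values lie within the scatter of each other, so compound 2 cannot be ranked against compound 1.

Next in the series is compound 3 `COC1=C(C)C(=O)/C(=C(O)/C=C/c2cccs2)C(=O)C1(C)C`, which carries thiophen-2-yl in place of 2,6-dimethylphenyl on a double-bonded chain carbon bound to a double-bonded chain carbon. The shared core stays the same.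

Within the data shown here, only one measured step bears on this change. That step, a 1.4-fold lower number from compound 1 to compound 2 (0.15 log units; within the scatter), exchanged one aromatic group for another at the same place and stayed within the scatter. Among the measured compounds shown here, this is thin evidence, and no five-membered aromatic ring has been measured so far. A step no larger than the scatter is therefore expected in this assay, with no firm direction. The estimated step is a 1.2-fold higher number from compound 2 to compound 3 (0.08 log units; within the scatter). Compound 3 is expected at 2.5 ug/mL, with an estimated range of 1 ug/mL to 6 ug/mL.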

Compound 3, concentration for half-maximal effect: 3.4 ug/mL
For compound 3 the middle estimate is 1.4-fold (0.13 log units) below the measured one; measured number inside the range.
By their numbers in this assay, from the lowest: compounds 2, 1 and 3 (each within the scatter of the next).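

In this assay, the exchange of a six-membered aromatic ring of carbon only for a five-membered aromatic ring with 1 hetero atom gives a 1.6-fold higher number from compound 2 to compound 3 (0.21 log units; within the scatter) and stays within the scatter, which extends the earlier picture from one kind of aromatic ring to two at this place, on a double-bonded chain carbon bound to a double-bonded chain carbon. The comparison with the hydroxylated ring reads the same way, with a 1.1-fold higher number from compound 1 to compound 3 (0.05 log units; within the scatter) also within the scatter, so 4-hydroxyphenyl, 2,6-dimethylphenyl and thiophen-2-yl cannot be ranked against one another in this assay. Ring size, the sulfur atom and the hydrogen-bond acceptor counted for thiophen-2-yl thus do not separate compound 3 from compound 2 here, and no supporting data are at hand to say why these values stay together.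

All three groups shown at this place are aromatic rings, so it remains open whether an aromatic ring is needed there at all. A cyclohexyl ring, an amine or a carboxylic acid at the same place would address that question, and the compounds shown say nothing about changes elsewhere on the shared core.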